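Removing the methoxy group from compound 1: an alpha-galactosidase probe

The source may hold more compounds than are shown below. What is called first, only, known or untested is meant among the compounds shown, and "the series" means these compounds.

The measured compounds:
compound 1 `COc1ccc(Br)cc1/C=C/C(=O)NC[C@H]1NC[C@H](O)[C@@H](O)[C@H]1O`, 47% in an assay on isolated protein for inhibition of alpha-galactosidase (Coffea arabica), read by spectrophotometry, tested at 100 uM; on this read-out higher numbers stand for more inhibition at the one concentration tested (going by the name of the read-out) and lower numbers for less inhibition
compound 2 `O=C(CCCCC1CCCCC1)NC[C@H]1NC[C@H](O)[C@@H](O)[C@H]1O`, 57% in this assay
compound 3 `COc1ccc(OC)c(/C=C/C(=O)NC[C@H]2NC[C@H](O)[C@@H](O)[C@H]2O)c1`, 57% in this assay

Among the three numbers compound 1 gives the lowest value, though its distance to compound 2 and to compound 3 is within the scatter, so none of the three can be called stronger or weaker than another. Among the measured compounds shown here, the one step in which two measured compounds differ in a single place runs a number 10 percentage points higher from compound 1 to compound 3 (within the scatter), and it lies within the scatter.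

Compound 4 `O=C(/C=C/c1cccc(Br)c1)NC[C@H]1NC[C@H](O)[C@@H](O)[C@H]1O` arises from compound 1 by the change (hydrogen in place of methoxy on an aromatic carbon). For the measured compounds named here, no measured step touches this position; the single change that has been measured exchanges bromo for methoxy at a different carbon and moved the number within the scatter. Nothing in these data, therefore, points to a step in either direction, and the expectation for this assay is a change no larger than the scatter.

Compound 4 is accordingly estimated at 45%, with a range from 28% to 62%. The estimated step of a number 2 percentage points lower from compound 1 to compound 4 (within the scatter) is expected to stay within the scatter.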

Compound 4, a percentage reported as inhibition, at one concentration (the size of the read-out at that concentration, not a potency): 56%
Estimate against measurement, compound 4: 11 percentage points below; the range from low to high includes it.
By their numbers in this assay, from the lowest: compounds 1, 4, 2 and 3 (each within the scatter of the next).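

The methoxy group on the aromatic carbon ortho to a large group and para to a bromo group had not been varied in any earlier step, and in this assay its replacement by hydrogen gives a number 9 percentage points higher from compound 1 to compound 4 (within the scatter). This carbon therefore takes hydrogen in place of methoxy, which removes 2 heavy atoms and 1 hydrogen-bond acceptor, without a readable difference in inhibition at the one concentration tested, so the methoxy group is not required for the inhibition seen with compound 1. No independent measurement is available that would explain this result.

From the compounds shown here alone, it remains open whether a different group on this carbon, such as an amine, a carboxylic acid or a longer chain, would move the number beyond the scatter, and whether the bromo group matters once the methoxy group is absent. Each compound was tested at one concentration, and each number lies within the scatter of the next. The relative potency of the compounds shown remains unresolved.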